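Replacing a phenol hydrogen with an aminotriazolylmethyl group

The source may hold more compounds than are shown below. What is called first, only, known or untested is meant among the compounds shown, and "the series" means these compounds.

Of the compounds shown here, three have been measured in a functional assay for agonist activity at Bombesin receptor subtype-3 (Homo sapiens); on this read-out lower numbers stand for an effect already at smaller amounts and higher numbers for an effect only at larger amounts of compound. Compound 1 `CCC(C)(C)Cc1c[nH]c(CCc2ccc(-c3ccccc3O)cc2)n1` gives 133 nM, which places it second highest of the three numbers. Its nearest neighbour, compound 3 `CCC(C)(C)Cc1c[nH]c(CCc2ccc(-c3ccccc3OCC(=O)O)cc2)n1`, gives 54 nM, and the furthest, compound 2 `O=C1NC(=O)C(c2ccccc2-c2ccc(CCC3N=CC(CC4CCCC4)=N3)cc2)S1`, gives 1770 nM.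

Compound 4 `CCC(C)(C)Cc1c[nH]c(CCc2ccc(-c3ccccc3OCc3nc(N)n[nH]3)cc2)n1` has not been measured. It differs from compound 1 in one place: (3-amino-1H-1,2,4-triazol-5-yl)methyl in place of hydrogen on an oxygen on an aromatic ring, and the same difference, cut one bond further out, reads hydroxy to (3-amino-1H-1,2,4-triazol-5-yl)methoxy.

Going by the values given here, only one measured step touches the same oxygen: a 2.5-fold lower number from compound 1 to compound 3 (0.39 log units; beyond the scatter). That step attached a carboxymethyl group, whereas compound 4 carries a ring with two hydrogen-bond donors and three acceptors, so the step does not transfer directly. Among the compounds with values here, compound 2 shares no single-point step with compound 1 and only shows its own value.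

On this basis a modest downward step is expected, a 1.9-fold lower number from compound 1 to compound 4 (0.28 log units; within the scatter), with the number for compound 4 estimated at 70 nM, between 25 nM and 250 nM in this assay.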

Compound 4, half-maximal effective concentration: 78 nM
For compound 4 the middle estimate is 1.1-fold (0.05 log units) below the measured one, and the stated range covers the measured number.
By their numbers in this assay, from the lowest: compounds 3, 4 and 1 (each within the scatter of the next, the first and the last beyond it); then compound 2.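

In this assay the oxygen on the aromatic ring accepts a (3-amino-1H-1,2,4-triazol-5-yl)methyl group without a clear shift, with a 1.7-fold lower number from compound 1 to compound 4 (0.23 log units; within the scatter), so capping the hydroxy with this ring costs nothing measurable. The carboxy group of compound 3 is also not essential for a number of this size, since replacing it with 3-amino-1H-1,2,4-triazol-5-yl gives a 1.4-fold higher number from compound 3 to compound 4 (0.16 log units; within the scatter), which leaves compound 4 unresolved from both compound 1 and compound 3. Nothing available explains why these groups read so alike.

Going by these compounds, it stays open whether the triazole ring contributes at all, and a plain methyl or a 2-aminoethyl group on the same oxygen would help to test that. A longer chain carrying the carboxylic acid, such as 3-carboxypropyl, would show how far this position reaches.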